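The source may report more compounds than this note shows. Statements on the series, on what has been measured and on what is new or still open speak of the compounds shown alone.

Measured compounds:
- compound 1, `O=C1Nc2ccc(Br)cc2/C1=N/NC(=S)Nc1ccc(Cl)cc1`, giving 29000 nM
- compound 2, `Cc1ccc(CN2C(=O)/C(=N\NC(=S)Nc3ccc(Cl)cc3)c3cc(Br)ccc32)cc1`, giving 74000 nM

In a functional assay on MOLT-4 cells (Homo sapiens), with a stated time of 72 h (on this read-out higher numbers stand for weaker inhibition and lower numbers for stronger inhibition), compound 1 gives 29000 nM, and compound 2 gives 74000 nM. Among the compounds with values here, compound 2 thus holds the higher of the two numbers; its only neighbour is compound 1, and the gap between them is a 2.6-fold higher number from compound 1 to compound 2 (0.41 log units; beyond the scatter), which comes with 4-methylbenzyl in place of hydrogen on an amide-type nitrogen in a ring. Compound 3, `O=C1/C(=N\NC(=S)Nc2ccc(Cl)cc2)c2cc(Br)ccc2N1Cc1ccc(Cl)cc1`, has not yet been measured in this assay. It differs from compound 2 by chloro in place of methyl on an aromatic carbon, an exchange that read one bond further out is 4-methylbenzyl to 4-chlorobenzyl. Within the data shown here, no measured pair shows this exchange: the single known step concerns the whole benzyl group and offers no guide to what is carried on it. With nothing pointing either way, the change is expected to leave the number close to that of compound 2, so the step expected in this assay, a 1.1-fold lower number from compound 2 to compound 3 (0.02 log units; within the scatter), should stay within the usual scatter. Compound 3 is therefore estimated at 70000 nM, with a range from 30000 nM to 170000 nM.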

Compound 3, half-maximal inhibitory concentration: 280000 nM
Beside the measured number, compound 3's estimate is 4.0-fold (0.60 log units) below it, outside the stated range (above it).
By their numbers in this assay, from the lowest: compound 1; then compound 2; then compound 3.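

In this assay, what the benzyl group carries proves to matter: there is a 3.8-fold higher number from compound 2 to compound 3 (0.58 log units; beyond the scatter) with chloro in place of methyl on an aromatic carbon para to a large group, although one heavy atom simply replaces another and no hydrogen-bond donor or acceptor enters or leaves. The earlier pair showed only that a substituent on the amide-type nitrogen raised the number, with a 2.6-fold higher number from compound 1 to compound 2 (0.41 log units; beyond the scatter) for 4-methylbenzyl in place of hydrogen, whereas 4-chlorobenzyl in place of hydrogen gives a 9.7-fold higher number from compound 1 to compound 3 (0.98 log units; beyond the scatter) and so shows that the size of this rise depends on the group at the far end of the benzyl ring. Nothing available here accounts for the change.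

As far as these compounds go, what an unsubstituted benzyl, a methoxy group, an amine or a carboxylic acid at this same place would give remains open, so two groups alone cannot define a trend. It is also unknown whether the exchange of methyl for chloro would act in the same way on a core carrying something other than the groups shown.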